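A few compounds are considered here, and "the series" means these few. Any claim that something is new, unique, unknown or untested is made for them only; others in the source may bear on it.

Compound 1 `Cn1ccc2c(Oc3ccc(NC(=O)c4nn(-c5ccc(Br)cc5)ccc4=O)cc3F)ccnc21` and compound 2 `Cn1ccc2c(Oc3ccc(NC(=O)c4nn(-c5ccc(Br)cc5F)ccc4=O)cc3F)ccnc21` share one core, and compound 2 differs only by fluoro in place of hydrogen on an aromatic carbon. In a functional assay on HepG2 cells (Homo sapiens) for cytotoxicity, read by MTT assay, with a stated time of 72 h (a higher number here means a weaker inhibitor, a lower number a stronger inhibitor), compound 1 sits at a limit of the assay, > 60000 nM. In this assay compound 2 gives 24000 nM, so the change made an at least 2.5-fold lower number from compound 1 to compound 2 (0.39 log units; beyond the scatter). Compound 3 `Cc1cc(=O)n(-c2ccc(F)cc2)nc1C(=O)Nc1ccc(Oc2ncnc3[nH]ccc23)cc1` stands on another core; the difference between the two cores is not broken down here. In this assay compound 3 also sits at a limit, > 60000 nM. Compound 4 `Cc1cc(=O)n(-c2ccc(F)cc2)nc1C(=O)Nc1ccc(Oc2ncnc3[nH]ccc23)c(F)c1` carries the same kind of change, (fluoro in place of hydrogen on an aromatic carbon); its place is ortho to a large group and meta to a large group, whereas in compound 2 it is meta to a bromo group. On these data alone, since compound 3 rests at the limit of > 60000 nM in this assay, at which 2 of the 3 values shown sit, its true starting point is unknown. Compound 4 is nonetheless expected to show a step of an at least 1.7-fold lower number from compound 3 to compound 4 (0.23 log units; that floor lies within the scatter), resting on an at least 2.5-fold lower number from compound 1 to compound 2 (0.39 log units; beyond the scatter). Compound 4 is estimated at 35000 nM, between 15000 nM and 80000 nM.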

Compound 4, half-maximal inhibitory concentration: 12900 nM
The estimate for compound 4 lay 2.7-fold (0.43 log units) above the measured number; the whole stated range lies above it.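

In this assay, fluoro in place of hydrogen on an aromatic carbon also lowers the number on the second core, giving an at least 4.6-fold lower number from compound 3 to compound 4 (0.66 log units; beyond the scatter). The change therefore moves the number in the same direction on both cores shown, and no compound here goes against that. This does not show that the size of the step carries over from one core to the other, since each step starts from a limit: the same change on two cores in this assay, an at least 2.5-fold lower number (0.39 log units; beyond the scatter) from compound 1 to compound 2 and an at least 4.6-fold lower number (0.66 log units; beyond the scatter) from compound 3 to compound 4; the limit leaves it open whether they differ

The compounds shown leave open how a chloro group or a methoxy group in place of the fluoro of compound 4 would compare. The true values of compound 1 and compound 3 also stay open: the limit of > 60000 nM in this assay, at which 2 of the 4 values shown sit.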